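Trading a formylphenyl for a fluorophenyl on the core

This account rests on a few compounds, and the source may have more. Where it says the series, first, only, none or still open, it means among the compounds named here.

Compound 1 `Brc1cn2ccnc2c(-c2ccc3ncn(C4CCCCC4)c3c2)n1`: 13.1%
Compound 2 `O=Cc1ccc(-c2cn3ccnc3c(-c3ccc4ncn(C5CCCCC5)c4c3)n2)cc1`: 49.1%
Compound 3 `Brc1ccc(-c2cn3ccnc3c(-c3ccc4ncn(C5CCCCC5)c4c3)n2)cc1`: 35.8%

In a functional assay on HCT-15 cells (Homo sapiens) for inhibition, read by sulforhodamine B assay, with a stated time of 48 h, tested at 10 uM (on this read-out higher numbers stand for more inhibition at the one concentration tested (going by the name of the read-out) and lower numbers for less inhibition), compound 2 stands highest of the three: the step of a number 36 percentage points higher from compound 1 to compound 2 (beyond the scatter) is large, and compound 3 sits below it by a number 13.3 percentage points lower from compound 2 to compound 3 (beyond the scatter). Compound 4 `Fc1ccccc1-c1cn2ccnc2c(-c2ccc3ncn(C4CCCCC4)c3c2)n1` is not yet measured; it differs from compound 2 in one place: 2-fluorophenyl in place of 4-formylphenyl on an aromatic carbon. The step that bears most on this change is a number 13.3 percentage points lower from compound 2 to compound 3 (beyond the scatter), where the formyl-bearing ring gave way to a bromo-bearing one and the number fell modestly; a number 22.7 percentage points higher from compound 1 to compound 3 (beyond the scatter) shows that such a phenyl group still sits well above bare bromo. A modest fall is therefore expected, a number 13.1 percentage points lower from compound 2 to compound 4 (beyond the scatter). For compound 4 the estimate is 36%, with a range from 18% to 54%.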

Compound 4, a percentage reported as inhibition, at one concentration (the size of the read-out at that concentration, not a potency): 6.18%
For compound 4 the middle estimate is 29.8 percentage points above the measured one; the measured number lies below the stated range.
By their numbers in this assay, from the lowest: compounds 4 and 1 (each within the scatter of the next); then compound 3; then compound 2.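

A phenyl ring at this position does not by itself lift the number: in this assay there is a number 42.9 percentage points lower from compound 2 to compound 4 (beyond the scatter) and also a number 29.6 percentage points lower from compound 3 to compound 4 (beyond the scatter) even though all three compounds carry a phenyl ring there. With a number 6.9 percentage points lower from compound 1 to compound 4 (within the scatter) the 2-fluorophenyl group shows no gain that can be told from bare bromo, so the earlier rise holds for 4-formylphenyl and 4-bromophenyl but not for every phenyl group. No measured evidence explains this difference.

Going by these compounds, it remains open whether the fluorine itself or its place on the ring matters, which a 4-fluorophenyl group could separate. On these data alone, how an amine or a carboxylic acid on the phenyl ring would read also remains open.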